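A few compounds are considered here, and "the series" means these few. Any claim that something is new, unique, unknown or untested is made for them only; others in the source may bear on it.

Compound 2 `Fc1ccc(C(c2ccc(F)cc2)C2CCN(CCCOc3ccc(Cl)cc3)CC2)cc1` gives 2 nM in a functional assay (aorta) with Oryctolagus cuniculus as the target (on this read-out lower numbers stand for tighter binding and higher numbers for weaker binding), the lowest of the two numbers, though compound 1 `CC(=O)c1ccc(OCCCN2CCC(C(c3ccc(F)cc3)c3ccc(F)cc3)CC2)cc1` gives 2.51 nM, and a 1.3-fold lower number from compound 1 to compound 2 (0.10 log units; within the scatter). Compound 3 `CN(CCCN1CCC(C(c2ccc(F)cc2)c2ccc(F)cc2)CC1)c1ccccc1` differs from compound 2 by methyl(phenyl)amino in place of 4-chlorophenoxy on a saturated chain carbon, three bonds along the chain from an amine nitrogen in a ring. Within the data shown here, the one measured step, from compound 1 to compound 2, changed only a group on the aromatic ring that now leaves, and it stayed within the scatter; no step swaps the ring oxygen for a nitrogen. Compound 3 is therefore expected near compound 2, with a wider range, at 3 nM between 1 nM and 10 nM, a step of a 1.5-fold higher number from compound 2 to compound 3 (0.18 log units; within the scatter).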

Compound 3, dissociation constant: 2 nM
Compound 3: middle estimate off by 1.5-fold (0.18 log units), on the high side; low and high end bracket the measured number.
By their numbers in this assay, from the lowest: compounds 2, 3 and 1 (each within the scatter of the next).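

In this assay, replacing the whole 4-chlorophenoxy with methyl(phenyl)amino gives no change at the digits printed from compound 2 to compound 3 (within the scatter), and replacing 4-acetylphenoxy with the same group gives a 1.3-fold lower number from compound 1 to compound 3 (0.10 log units; within the scatter). The earlier step changed only a group on the aromatic ring, whereas these show that the atom joining that ring to the saturated chain can also be exchanged, oxygen for a nitrogen bearing a methyl, with the read-out staying within the scatter. The compounds shown leave open whether an amide or a longer chain at this place would do the same. Nothing measured here says why this exchange is tolerated.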